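Adding a Second Methyl on a Cyanoguanidine Tail

The source may hold more compounds than are shown below. What is called first, only, known or untested is meant among the compounds shown, and "the series" means these compounds.

Compound 1 `C/N=C(/NC#N)NCCCCCCn1nc(-c2ccccc2)ccc1=O` is a cyanoguanidine with a single methyl on its terminal nitrogen, linked through a six-carbon chain to the core. In a functional assay on the whole organism (stomach) with Rattus norvegicus as the target (a higher number here means that more compound is needed for the effect, a lower number that less compound is needed), compound 1 gives no number, only the limit of the assay, > 100 mg/kg. Among the measured compounds shown here, this is the only thing known about compound 1, as recorded in the limit of > 100 mg/kg in this assay, at which 1 of the 2 values shown sits. Compound 2 `C/N=C(/NC#N)NCCCCn1nc(-c2ccccc2)cc(C)c1=O`, which has a shorter chain and an extra methyl on the core, gives 60.8 mg/kg in this assay.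

Compound 3 `CN(C)/C(=N/CCCCCCn1nc(-c2ccccc2)ccc1=O)NC#N` differs from compound 1 in one place: a group of 8 heavy atoms (4 carbon, 4 nitrogen; no ring) in place of a group of 7 heavy atoms (3 carbon, 4 nitrogen; no ring), on a saturated chain carbon, six bonds along the chain from an aromatic nitrogen. For the measured compounds named here, no measured pair shows what such a change does, so the step from compound 1 to compound 3 is expected to be small or none beyond the scatter, in either direction, a step that the limit leaves unreadable from compound 1 to compound 3. Compound 3 is estimated at 150 mg/kg, in a range from 50 mg/kg to 500 mg/kg, with a good chance that only a limit is reported.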

Compound 3, dose for half-maximal effect: 93.1 mg/kg
For compound 3 the middle estimate is 1.6-fold (0.21 log units) above the measured one; measured number inside the range.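

With a second methyl on the terminal nitrogen, the six-carbon chain now gives a true number in this assay, which compound 1 alone could not provide. The change amounts to an at least 1.0-fold lower number from compound 1 to compound 3 (0.03 log units; that floor lies within the scatter), so the data confirm only a floor for the step, and that floor does not show a real gain from the extra methyl. The true size of the step cannot be read because compound 1 has only a limit, not a number: the limit of > 100 mg/kg in this assay, at which 1 of the 3 values shown sits.

The compounds shown leave open what a larger group on this nitrogen would do, such as an ethyl group or a piperidine ring. They also leave open what chain length alone contributes: compound 2 differs from compound 3 in more than one place.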